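Estimating a dimethoxyphenyl swap on the hydroxylated core

The source may hold more compounds than are shown below. What is called first, only, known or untested is meant among the compounds shown, and "the series" means these compounds.

Values in a functional assay on DWD cells (Homo sapiens) for inhibition, read by sulforhodamine B assay (a higher number here means a weaker inhibitor of growth, a lower number a stronger inhibitor of growth), so far
- Compound 1 `COc1ccc(-c2ccc(-c3ccc(-c4nc5ccccc5[nH]4)cc3)cc2)cc1OC` gives 42100 nM
- Compound 2 `Oc1cccc2[nH]c(-c3ccc(-c4ccc(-c5ccccc5)cc4)cc3)nc12` gives 9680 nM
- Compound 3 `Oc1cccc2[nH]c(-c3ccc(-c4ccc(-c5ccc(OC(F)(F)F)cc5)cc4)cc3)nc12` gives 3100 nM

Compound 3 stands lowest of the three with 3100 nM and is the strongest growth inhibitor so far, with its gaps to both others beyond the scatter. Compound 4 `COc1ccc(-c2ccc(-c3ccc(-c4nc5c(O)cccc5[nH]4)cc3)cc2)cc1OC` has not yet been measured. Its difference from compound 3 is 3,4-dimethoxyphenyl in place of 4-(trifluoromethoxy)phenyl on an aromatic carbon and so 3,4-dimethoxyphenyl stands in place of 4-(trifluoromethoxy)phenyl on an aromatic carbon.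

For the measured compounds named here, one measured step bears on this place: a 3.1-fold lower number from compound 2 to compound 3 (0.49 log units; beyond the scatter) and it is modest. Compound 1 carries the same 3,4-dimethoxyphenyl group and gives 42100 nM but its core differs, so it cannot isolate the effect of that group. Going by the values given here, no measured pair does. Among the compounds with values here, a small rise in the number is therefore expected in this assay with a size no larger than the one measured step, and possibly within the scatter. The estimated change is a 1.9-fold higher number from compound 3 to compound 4 (0.29 log units; within the scatter) in this reading. For compound 4 the estimate is 6000 nM with an expected range from 2000 nM to 18000 nM as the likely span.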

Compound 4, concentration for 50% growth inhibition: 1400 nM
The estimate for compound 4 lay 4.3-fold (0.63 log units) above the measured number, and the stated range ends above it.
By their numbers in this assay, from the lowest: compound 4; then compound 3; then compound 2; then compound 1.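

In this assay, 3,4-dimethoxyphenyl at this place, on an aromatic carbon para to a large group, does better than 4-(trifluoromethoxy)phenyl, with a 2.2-fold lower number from compound 3 to compound 4 (0.35 log units; beyond the scatter). Measured against plain phenyl, the same group gives a 6.9-fold lower number from compound 2 to compound 4 (0.84 log units; beyond the scatter), which goes further than a 3.1-fold lower number from compound 2 to compound 3 (0.49 log units; beyond the scatter), so both substituted end rings lower the number and the dimethoxy one lowers it more. The hydroxy group can now be read on its own with the 3,4-dimethoxyphenyl group held constant, and it gives a 30-fold lower number from compound 1 to compound 4 (1.48 log units; beyond the scatter), the only large step among these compounds and larger than either change at the end ring.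

The compounds shown cover only phenyl, 4-(trifluoromethoxy)phenyl and 3,4-dimethoxyphenyl at this place, so it remains open how an end ring carrying an amine or a carboxylic acid would compare, and whether the hydroxy step would keep its size with another end ring. Nothing at hand accounts for the size or direction of any of these steps.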